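Swapping the Aryl Group on the Shared Core

The compounds below may be only part of what the source reports. "The series", "measured", "known", "first", "only" and "open" are said of these compounds alone.

Compound 2 `Oc1cc(C(F)(F)F)ccc1-c1nc(-c2ccccc2O)n(-c2ccc(OC(F)(F)F)cc2)n1` gives 92.5% in a functional assay on PC-12 cells (Rattus norvegicus) for cytotoxicity, read by MTT assay, with stated times of 2 h and 24 h, tested at 10 uM; a higher number here means a stronger effect of the compound at the concentration tested, a lower number a weaker effect. Of the three numbers measured, that of compound 2 is the lowest, yet neither compound 3 `Oc1cc(C(F)(F)F)ccc1-c1nc(-c2ccccc2O)n(-c2ccccc2F)n1` with 100% nor compound 1 `Cc1ccc(-n2nc(-c3ccc(C(F)(F)F)cc3O)nc2-c2ccccc2O)cc1` with 102% differs from it beyond the scatter. Compound 4 `Oc1cc(C(F)(F)F)ccc1-c1nc(-c2ccccc2O)n(-c2cc(F)cc(F)c2)n1` differs from compound 2 by one change: 3,5-difluorophenyl in place of 4-(trifluoromethoxy)phenyl on an aromatic nitrogen. Two measured steps exchange the group on the same aromatic nitrogen: a number 7.5 percentage points higher from compound 2 to compound 3 (within the scatter) and a number 2 percentage points lower from compound 1 to compound 3 (within the scatter), both within the scatter. Since neither moves the read-out beyond the scatter, no step beyond the scatter is expected here either. The expected step is a number 5.5 percentage points higher from compound 2 to compound 4 (within the scatter). Compound 4 is therefore estimated at 98%, with a range from 88% to 108%.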

Compound 4, a percentage reported as activity, at one concentration (the size of the read-out at that concentration, not a potency): 106%
Compound 4: the middle estimate sits 8 percentage points below what was measured; low and high end bracket the measured number.
By their numbers in this assay, from the lowest: compounds 2, 3, 1 and 4 (each within the scatter of the next, the first and the last beyond it).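

this assay shows a number 13.5 percentage points higher from compound 2 to compound 4 (beyond the scatter) as the first exchange on this aromatic nitrogen to pass the scatter. The 3,5-difluorophenyl group stands apart only from 4-(trifluoromethoxy)phenyl, since a number 6 percentage points higher from compound 3 to compound 4 (within the scatter) and a number 4 percentage points higher from compound 1 to compound 4 (within the scatter) both stay within the scatter. Nothing measured here explains this modest gap.

All the groups shown at this position are phenyl rings bearing methyl, fluorine or trifluoromethoxy. From the compounds shown here alone, how an amine or a carboxylic acid on that ring, or a longer chain in its place, would read remains open.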